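The source may hold more compounds than are shown below. What is called first, only, known or untested is meant among the compounds shown, and "the series" means these compounds.

Working notes on the series. Compound 1, `C=CC1=C(C(=O)NCCCCC)C(c2ccc(Cl)c(Cl)c2)OC1`, carries a pentyl group on its amide nitrogen and a dichlorophenyl group on the shared core. In a functional assay on A549 cells (Homo sapiens) for cytotoxicity, read by MTT assay, with a stated time of 24 h (a lower number here means a stronger inhibitor, a higher number a weaker inhibitor), compound 1 gives > 100000 nM, which is a limit of the assay and not a number. Within the data shown here, compound 2, `C=CC1=C(C(=O)O)C(c2ccc(OC)cc2)OC1`, has a free carboxylic acid and a methoxyphenyl group in place of those groups; it differs from compound 1 in more than one place, so no single step between them can be read. In this assay compound 2 gives > 100000 nM, again a limit and not a number. Compound 1 therefore stands nowhere that can be ranked: both values sit at the limit of > 100000 nM in this assay, at which 2 of the 2 values shown sit, and nothing in the data separates the two.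

Compound 3, `C=CC1=C(C(=O)Nc2ccccc2)C(c2ccc(Cl)c(Cl)c2)OC1`, is the next member to be measured in this assay. It differs from compound 1 by phenyl in place of pentyl on an amide-type nitrogen. Among the measured compounds shown here, with no measured step available for guidance, no shift beyond the scatter is expected; the step from compound 1 to compound 3 is estimated as a step that the limit leaves unreadable from compound 1 to compound 3. Compound 3 is accordingly expected to give about 150000 nM in this assay, with an estimated range from 30000 nM to 500000 nM, and the value may well again come back only as a limit.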

Compound 3, half-maximal inhibitory concentration: > 100000 nM
Compound 3: no number, only a limit (the forecaster's own chance of this, stated with the estimate: 80%); the middle value is on the limit's open side.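

The step from compound 1 to compound 3, phenyl in place of pentyl on an amide-type nitrogen, cannot be read, since both compounds return only a limit and not a number: the limit of > 100000 nM in this assay, at which 3 of the 3 values shown sit.

The compounds shown leave open whether any member of the series gives a measurable value in this assay, and what any single change on the shared core does to that value.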